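The source may report more compounds than this note shows. Statements on the series, on what has been measured and on what is new or still open speak of the compounds shown alone.

Working notes on the series. Compound 1 (`N#CC1=C(N)Oc2c(N)cc3nc4ccccc4nc3c2C12C(=O)N(Cc1cnnn1-c1ccc(F)cc1)c1ccccc12`) has been run in a functional assay on MCF7 cells (Homo sapiens) for antiproliferative activity, read by MTT assay, with a stated time of 48 h; a higher number here means a weaker inhibitor, a lower number a stronger inhibitor. In this assay compound 1 reaches only > 50000 nM, which is a limit of the assay and not a number. Compound 2 (`CCOc1ccccc1-n1nncc1CN1C(=O)C2(C(C#N)=C(N)Oc3c(N)cc4nc5ccccc5nc4c32)c2ccccc21`) carries 2-ethoxyphenyl in place of 4-fluorophenyl on an aromatic nitrogen. In this assay compound 2 likewise gives > 50000 nM, again a limit rather than a measured number. The step that the two limits leave unreadable from compound 1 to compound 2 therefore cannot be read, since (the limit of > 50000 nM in this assay, at which 2 of the 2 values shown sit). Compound 2 thus stands at the assay limit, with no measured number in the series to place it against.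

Compound 3 (`Cc1ccc(-n2nncc2CN2C(=O)C3(C(C#N)=C(N)Oc4c(N)cc5nc6ccccc6nc5c43)c3ccccc32)cc1C`) has not yet been measured in this assay. It differs from compound 2 by 3,4-dimethylphenyl in place of 2-ethoxyphenyl on an aromatic nitrogen. Among the compounds with values here, the one measured step bears on the same aromatic nitrogen, but its size is not readable and both of its ends sit at the limit, so no direction can be taken from it. The expectation for compound 3 is that it also stays at the limit, with a step that the limit leaves unreadable from compound 2 to compound 3 estimated as no step beyond the scatter. The estimate for compound 3 is 80000 nM, with a range from 30000 nM to 300000 nM.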

Compound 3, half-maximal inhibitory concentration: > 50000 nM
Compound 3: no number, only a limit; the forecaster's own chance of this, stated with the estimate: 85%; the middle value does not contradict the limit.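

Compound 3 also gives only a limit and not a number, so neither the step from compound 1 nor the step from compound 2 to compound 3 can be read: the limit of > 50000 nM in this assay, at which 3 of the 3 values shown sit.

Left open is how 4-fluorophenyl, 2-ethoxyphenyl and 3,4-dimethylphenyl on the aromatic nitrogen compare in this assay and whether any compound on the shared core gives a measured number there.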